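Swapping the Ring Nitrogen Substituent and Expected Clearance

The compounds below may be only part of what the source reports. "The series", "measured", "known", "first", "only" and "open" are said of these compounds alone.

Measured compounds:
- compound 1, `CCCC[C@H](NC(=O)O[C@@H]1C(=O)N(S(=O)(=O)c2ccccc2)CC1(C)C)C(=O)C(=O)N[C@H](C)c1ccccc1`, 27 mL/min/kg
- compound 2, `CCCC[C@H](NC(=O)O[C@@H]1C(=O)N(C(=O)c2nc3ccccc3s2)CC1(C)C)C(=O)C(=O)Nc1cc[nH]n1`, 65 mL/min/kg

Within the data shown here, in an in vivo ADME assay on the whole organism (strain Han Wistar) for pharmacokinetics, with Rattus norvegicus as the target (on this read-out lower numbers stand for slow clearance and higher numbers for fast clearance), compound 1 gives 27 mL/min/kg, the lower of the two numbers known here. Compound 2 gives 65 mL/min/kg in this assay, and the gap between these two compounds lies beyond the usual scatter; the two structures differ in more than one place, so no single change can be tied to that gap.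

Compound 3, `CCCC[C@H](NC(=O)O[C@@H]1C(=O)N(C(=O)Nc2c(C)noc2C)CC1(C)C)C(=O)C(=O)N[C@H](C)c1ccccc1`, has not yet been measured in this assay. It differs from compound 1 in one place: (3,5-dimethyl-1,2-oxazol-4-yl)carbamoyl in place of phenylsulfonyl on an amide-type nitrogen in a ring.

Among the measured compounds shown here, no measured pair shows this exact change, so the direction cannot be read from the data. The step from compound 1 is expected to be a modest one, a 1.5-fold higher number from compound 1 to compound 3 (0.17 log units; within the scatter), with a wide range. Compound 3 is estimated to give 40 mL/min/kg in this assay, somewhere between 20 mL/min/kg and 80 mL/min/kg.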

Compound 3, clearance: 83 mL/min/kg
Compound 3: middle estimate off by 2.1-fold (0.32 log units), on the low side, and the stated range ends below it.
By their numbers in this assay, from the lowest: compound 1; then compounds 2 and 3 (each within the scatter of the next).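

Among these compounds, this is the first comparison in the set that changes only one place, the amide-type nitrogen in the ring, and it shows that this assay responds to the group placed there. Replacing phenylsulfonyl with (3,5-dimethyl-1,2-oxazol-4-yl)carbamoyl gives a 3.1-fold higher number from compound 1 to compound 3 (0.49 log units; beyond the scatter) and so moves clearance by more than the usual scatter, leaving phenylsulfonyl as the slower-cleared group of this pair. Nothing available here explains the rise.

The swap replaces the sulfonyl link and the phenyl ring together, so the compounds shown cannot say which part drives the step. On these data alone, a phenylcarbamoyl group, which pairs the phenyl ring of compound 1 with the carbamoyl link of compound 3, would separate the two, and how far other groups at this position shift clearance also remains open.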